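The source may report more compounds than this note shows. Statements on the series, on what has been measured and on what is new or still open speak of the compounds shown alone.

Measured so far:
compound 1 `S=C(NCc1ccccc1)Nc1ccc2ncnc(Nc3ccccc3Br)c2c1` | > 30000 nM
compound 2 `Fc1ccc(NC(=S)Nc2ccc3ncnc(Nc4cccc(Br)c4)c3c2)cc1Cl` | 300 nM

Among the measured compounds shown here, in a functional assay on MDA-MB-231 cells (Homo sapiens) for inhibition, read by MTT assay, with a stated time of 48 h (a higher number here means a weaker inhibitor of growth, a lower number a stronger inhibitor of growth), compound 2 gives 300 nM and, of the two compounds tested, holds the only actual number. Compound 1 reads > 30000 nM and this is a limit of the assay, not a number.

Compound 3 `S=C(Nc1cc(Cl)cc(Cl)c1)Nc1ccc2ncnc(Nc3cccc(Br)c3)c2c1` has not yet been measured. It departs from compound 2 in one place: 3,5-dichlorophenyl in place of 3-chloro-4-fluorophenyl on an amide-type nitrogen. In other words, 3,5-dichlorophenyl stands in place of 3-chloro-4-fluorophenyl on an amide-type nitrogen whose other neighbour is the thiocarbonyl carbon, and the rest of the structure is unchanged.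

For the measured compounds named here, no measured pair shows what such a swap does in this assay, so the expectation is anchored on compound 2 at 300 nM and carries a wide margin. Only a small shift toward weaker growth inhibition is expected, perhaps no more than the usual scatter, and the expected step is a 1.3-fold higher number from compound 2 to compound 3 (0.12 log units; within the scatter). For compound 3 the estimated value is 400 nM, with an expected range from 120 nM to 1500 nM.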

Compound 3, concentration for 50% growth inhibition: 3000 nM
For compound 3 the middle estimate is 7.5-fold (0.88 log units) below the measured one; measured number above the stated range.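

In this assay, the group on the amide-type nitrogen whose other neighbour is the thiocarbonyl carbon proves sensitive to a change that keeps its size by count: 3,5-dichlorophenyl in place of 3-chloro-4-fluorophenyl gives a 10-fold higher number from compound 2 to compound 3 (1.00 log units; beyond the scatter). Both groups hold 8 heavy atoms and one six-membered aromatic ring of carbon only, with 0 hydrogen-bond donors and 0 hydrogen-bond acceptors, so these counts do not separate them, yet growth inhibition still moves beyond the scatter with the halogens the ring carries. Compound 1 cannot be set against this step, since its reading is a limit of the assay and not a number: the limit of > 30000 nM in this assay, at which 1 of the 3 values shown sits.

A single pair cannot tell whether the step follows the departure of fluorine, the arrival of the second chlorine, or the different placement of the halogens, and the compounds shown leave open how 3-chlorophenyl or 4-fluorophenyl alone would read at this nitrogen. They also leave open what a methoxy group, a nitrile or a carboxylic acid on this ring would do in this assay.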